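Alkyne terminus swaps in the series

The source may hold more compounds than are shown below. What is called first, only, known or untested is meant among the compounds shown, and "the series" means these compounds.

Compound 1 `CNC(=O)[C@@]12C[C@@H]1[C@@H](n1cnc3c(NC)nc(C#Cc4ccccc4OC)nc31)[C@H](O)[C@@H]2O` gives 0.77 nM in an assay on CHO cells for displacement of a labelled ligand from adenosine receptor A3 (Homo sapiens), read by scintillation counting, with a stated time of 60 min; a higher number here means a weaker inhibitor, a lower number a stronger inhibitor. Compound 2 `CCc1ccc(C#Cc2nc(NC)c3ncn([C@H]4[C@H](O)[C@H](O)[C@]5(C(=O)NC)C[C@H]45)c3n2)o1` gives 1.5 nM. Compound 3 `CNC(=O)[C@@]12C[C@@H]1[C@@H](n1cnc3c(NC)nc(C#Cc4ccsc4)nc31)[C@H](O)[C@@H]2O` gives 0.52 nM.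

Compound 3 carries the smallest of the three numbers, though its gap to compound 1 is within the scatter (a 1.5-fold lower number from compound 1 to compound 3 (0.17 log units; within the scatter)), while the gap on the other side is modest (a 2.9-fold lower number from compound 2 to compound 3 (0.46 log units; beyond the scatter)). Compound 4 `CNC(=O)[C@@]12C[C@@H]1[C@@H](n1cnc3c(NC)nc(C#CC4CCCCC4)nc31)[C@H](O)[C@@H]2O` differs from compound 3 by cyclohexyl in place of thiophen-3-yl on a triple-bonded carbon. Among the measured compounds shown here, no measured step exchanges an aromatic ring for a non-aromatic one, so the bearing of the measured steps is indirect: the three aromatic swaps a 1.9-fold higher number from compound 1 to compound 2 (0.29 log units; within the scatter), a 1.5-fold lower number from compound 1 to compound 3 (0.17 log units; within the scatter) and a 2.9-fold lower number from compound 2 to compound 3 (0.46 log units; beyond the scatter) all stayed small. A modest rise in the number is therefore expected, a 2.9-fold higher number from compound 3 to compound 4 (0.46 log units; beyond the scatter). Compound 4 is estimated at 1.5 nM, with a range of 0.4 nM to 6 nM.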

Compound 4, inhibition constant: 1.68 nM
Beside the measured number, compound 4's estimate is 1.1-fold (0.05 log units) below it; the range from low to high includes it.
By their numbers in this assay, from the lowest: compounds 3, 1, 2 and 4 (each within the scatter of the next, the first and the last beyond it).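

A non-aromatic ring is compatible with single-digit nanomolar numbers on the triple-bonded carbon in this assay, so an aromatic ring is not required here for a low number. Cyclohexyl gives modest rises against two aromatic groups (a 3.2-fold higher number from compound 3 to compound 4 (0.51 log units; beyond the scatter); a 2.2-fold higher number from compound 1 to compound 4 (0.34 log units; beyond the scatter)), but compound 4 cannot be separated from the 5-ethylfuran-2-yl compound (a 1.1-fold higher number from compound 2 to compound 4 (0.05 log units; within the scatter)). No supporting data explain these steps.

Open, as far as these compounds go, is whether a smaller ring such as cyclopropyl, a longer alkyl chain, an amine or a carboxylic acid on the triple-bonded carbon keeps numbers of this size.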